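Working notes: from compound 2 to compound 4

The source may hold more compounds than are shown below. What is called first, only, known or untested is meant among the compounds shown, and "the series" means these compounds.

Measured so far:
compound 1 `CC1CCC(=NNc2ccccc2C(=O)O)c2ncc(C(=O)O)c(=O)n21` — > 100 umol/kg
compound 2 `Cc1ccc(NN=C2CCC(C)n3c2ncc(C(=O)O)c3=O)cc1C` — > 100 umol/kg
compound 3 `Cc1cc(C)c(NN=C2CCC(C)n3c2ncc(C(=O)O)c3=O)cc1C` — 320 umol/kg

In a functional assay on the whole organism with Rattus norvegicus as the target (on this read-out higher numbers stand for an effect only at larger amounts of compound and lower numbers for an effect already at smaller amounts), compound 1 gives only a limit, > 100 umol/kg. Compound 2 likewise gives only a limit, > 100 umol/kg, so its standing in this assay is known as a limit, not as a number, and one further value of the three is a limit as well (the limit of > 100 umol/kg in this assay, at which 2 of the 3 values shown sit). Compound 3 gives 320 umol/kg. For the measured compounds named here, the single measured step, a step that the limit leaves unreadable from compound 2 to compound 3, cannot be read in size because the value of compound 2 is the limit (the limit of > 100 umol/kg in this assay, at which 2 of the 3 values shown sit).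

Compound 4 `CC1CCC(=NNc2cc(Cl)cc(Cl)c2)c2ncc(C(=O)O)c(=O)n21` is not yet measured. Its difference from compound 2 is 3,5-dichlorophenyl in place of 3,4-dimethylphenyl on an amine nitrogen. Going by the values given here, no measured step bears on this exchange; the one step, a step that the limit leaves unreadable from compound 2 to compound 3, gives no readable size, so nothing here points to a large shift in either direction. Compound 4 is therefore expected to stay weak in this assay, at 300 umol/kg, within 100 umol/kg to 1000 umol/kg. This estimate means an expected step that the limit leaves unreadable from compound 2 to compound 4, with a high chance that only a limit is reported again.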

Compound 4, dose for 50% inhibition: > 100 umol/kg
Compound 4 ended at the assay's limit (the forecaster's own chance of this, stated with the estimate: 60%); the middle value does not contradict the limit.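

In this assay compound 4 gives > 100 umol/kg, a limit and not a number. No step from compound 2 to compound 4 can be read, because both compounds sit at that limit: the limit of > 100 umol/kg in this assay, at which 3 of the 4 values shown sit.

The compounds shown leave open whether 3,5-dichlorophenyl in place of 3,4-dimethylphenyl changes the dose at all.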